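Inverting One Ring Stereocentre in a Weak Nicotinic Ligand

The source may hold more compounds than are shown below. What is called first, only, known or untested is meant among the compounds shown, and "the series" means these compounds.

Of the compounds shown here, two have been measured in an assay on HEK293 cells for displacement of a labelled ligand from Neuronal acetylcholine receptor; alpha3/beta4 (Homo sapiens), with a stated time of 5 min; on this read-out higher numbers stand for weaker inhibition and lower numbers for stronger inhibition. Compound 1 `CN1CCC[C@H]1[C@H]1COc2ccncc2O1` gives 8900 nM in this assay, while compound 2 `CN1CCC[C@H]1[C@H]1COc2ncccc2O1` gives 22000 nM there. Compound 2 thus stands at the higher of the two numbers, and the gap to compound 1 is beyond the usual scatter of such measurements.

Compound 3 `CN1CCC[C@H]1[C@@H]1COc2ncccc2O1` is the next compound to be measured. Relative to compound 2 the change is the two compounds have the same atoms and bonds and differ only in configuration as drawn: 1 of 2 stereo elements differ; a stereocentre at a saturated ring carbon is drawn S in compound 2 and R in compound 3: the two compounds have the same atoms and bonds and differ only in configuration as drawn; a stereocentre at a saturated ring carbon is drawn S in compound 2 and R in compound 3.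

Within the data shown here, no measured pair here shows such an inversion alone, so its effect in this assay is not known from the data. For compound 3 a step of moderate size in either direction is considered possible, and the expected change from compound 2 is a 1.1-fold lower number from compound 2 to compound 3 (0.04 log units; within the scatter). Compound 3 is therefore estimated to give about 20000 nM in this assay, with a range from 6000 nM to 70000 nM.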

Compound 3, inhibition constant: 16200 nM
The estimate for compound 3 lay 1.2-fold (0.09 log units) above the measured number, and the stated range covers the measured number.
By their numbers in this assay, from the lowest: compounds 1, 3 and 2 (each within the scatter of the next, the first and the last beyond it).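

In this assay, inverting the stereocentre at the saturated ring carbon gives a 1.4-fold lower number from compound 2 to compound 3 (0.13 log units; within the scatter), so the S and R forms at this position are not told apart beyond the scatter. Among these compounds, this is the first pair in the set that isolates a single change, and it can be read cleanly for one reason: the fact that compounds 2 and 3 differ only in the configuration as drawn. The inversion at this one stereocentre therefore gives no handle on the number in this assay, at least on the core shared by this pair.

From the compounds shown here alone, whether the same inversion would be equally silent on the core of compound 1, and whether the second stereocentre matters, remains open. Going by these compounds, it is also open whether a fluorine atom or an ethyl group on the shared core would move the number further than this inversion does.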